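The source may report more compounds than this note shows. Statements on the series, on what has been measured and on what is new or still open speak of the compounds shown alone.

Measured compounds:
compound 1 `CCN(Cc1ccc2nc(C)[nH]c(=O)c2c1)c1ccc(C(=O)N[C@@H](CCC(=O)O)C(=O)O)c(C)c1` — 320 nM
compound 2 `Cc1nc2ccc(CN(C)c3ccc(C(=O)N[C@@H](CCC(=O)O)C(=O)O)c(F)c3)cc2c(=O)[nH]1` — 120 nM

In an assay on isolated protein for inhibition of Thymidylate synthase (Mus musculus) (on this read-out higher numbers stand for weaker inhibition and lower numbers for stronger inhibition), compound 2 holds the lower of the two numbers; compound 1 gives 320 nM, a gap that lies beyond the usual scatter. Compound 3 `Cc1nc2ccc(CN(C)c3ccc(C(=O)N[C@@H](CCC(=O)O)C(=O)O)c(C)c3)cc2c(=O)[nH]1` is not yet measured in this assay. It differs from compound 2 by methyl in place of fluoro on an aromatic carbon, a methyl in place of fluoro on an aromatic carbon. Among the measured compounds shown here, compound 1 also carries a methyl at that aromatic carbon, though it differs from compound 2 in a second place as well, so no single step links them. The step from compound 2 to compound 3 is expected to be a modest rise, at the edge of the scatter or a little beyond it a 2.0-fold higher number from compound 2 to compound 3 (0.30 log units; within the scatter). For compound 3 the estimate is 240 nM, within a range from 100 nM to 600 nM.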

Compound 3, half-maximal inhibitory concentration: 940 nM
Compound 3: middle estimate off by 3.9-fold (0.59 log units), on the low side, outside the stated range (above it).
By their numbers in this assay, from the lowest: compound 2; then compound 1; then compound 3.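

In this assay, this aromatic carbon proves sensitive to the exchange: methyl in place of fluoro gives a 7.8-fold higher number from compound 2 to compound 3 (0.89 log units; beyond the scatter) and is a step beyond the scatter. With that methyl held constant, hydrogen in place of methyl on the saturated chain carbon bound to the nitrogen gives a 2.9-fold higher number from compound 1 to compound 3 (0.47 log units; beyond the scatter) and so shows that this second site also matters. Nothing available accounts for either step. The compounds shown leave open how chloro or plain hydrogen on that aromatic carbon would compare, and whether fluoro and the longer nitrogen chain of compound 1 would add together.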